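A ring exchange on the amide-type nitrogen of compound 3

The source may report more compounds than this note shows. Statements on the series, on what has been measured and on what is new or still open speak of the compounds shown alone.

Measured in an ADME assay on MT4 cells (Homo sapiens) for cytotoxicity, read by MTT assay, with a stated time of 5 days; on this read-out higher numbers stand for lower toxicity in this test and lower numbers for higher toxicity in this test:
- Compound 1 `COc1cc2nc(Nc3ccc(C#N)cc3)nc(Nc3c(Cl)cc(/C=C/C#N)cc3Cl)c2cc1OC`: 9920 nM
- Compound 2 `COc1cc2nc(SCC(=O)Nc3ccc(C)cc3)nc(Nc3c(Cl)cc(/C=C/C#N)cc3Cl)c2cc1OC`: 2540 nM
- Compound 3 `COc1cc2nc([S+]([O-])CC(=O)Nc3ccc(Cl)cc3)nc(Nc3c(Cl)cc(/C=C/C#N)cc3Cl)c2cc1OC`: 14400 nM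

Compound 3, at 14400 nM, lies within the usual scatter of compound 1. Its number is clearly higher than that of compound 2.

Compound 4 `COc1cc2nc([S+]([O-])CC(=O)Nc3cccc(C#N)c3)nc(Nc3c(Cl)cc(/C=C/C#N)cc3Cl)c2cc1OC` carries 3-cyanophenyl in place of 4-chlorophenyl on an amide-type nitrogen. For the measured compounds named here, no measured step covers a change in that place. The only one available is a 3.9-fold lower number from compound 1 to compound 2 (0.59 log units; beyond the scatter), and it is a replacement on an aromatic carbon, so it gives only a loose sense of how far this assay can move within this small set. With nothing closer to go on, compound 3 at 14400 nM is the natural starting point, and no change beyond the scatter is expected. The expected step is a 1.2-fold lower number from compound 3 to compound 4 (0.08 log units; within the scatter). For compound 4 the estimated value is 12000 nM, with an expected range from 4500 nM to 32000 nM.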

Compound 4, half-maximal cytotoxic concentration: >= 70300 nM
Compound 4: a limit, no number (the forecaster's own chance of this, stated with the estimate: 10%); middle value at least 5.8-fold (0.76 log units) from the limit.
By their numbers in this assay, from the lowest: compound 2; then compounds 1 and 3 (each within the scatter of the next). At a limit, above all of these: compound 4.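

Within this assay, the group on the amide-type nitrogen turns out to matter: 3-cyanophenyl in place of 4-chlorophenyl gives an at least 4.8-fold higher number from compound 3 to compound 4 (0.68 log units; beyond the scatter), whereas the earlier compounds offered no step at this place. This is the first change shown at that nitrogen, and it leaves the rest of compound 3 untouched. The reading for compound 4 is a limit of the assay and not a number: the limit of >= 70300 nM in this assay, at which 1 of the 4 values shown sits.

The exchange alters both the group on the ring and its position, and the compounds shown do not separate the two. They also leave open how a phenyl ring carrying a carboxylic acid or an amine, or a longer chain in place of the ring, would read in this assay.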